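Swapping the pyridine on the shared core: compound 4

This account rests on a few compounds, and the source may have more. Where it says the series, first, only, none or still open, it means among the compounds named here.

Three compounds share a common core and differ only in the aromatic group attached to one carbon of the five-membered ring. In a functional assay on BJAB cells (Homo sapiens) for antiproliferative activity, with a stated time of 4 days (a higher number here means that more compound is needed for the effect, a lower number that less compound is needed), compound 1 `COc1cncc(-c2c(C)nn(-c3nc(-c4ccc(Cl)c(Cl)c4)c(SC(C)C)s3)c2C(=O)O)c1` gives 21000 nM, and compound 2 `Cc1nn(-c2nc(-c3ccc(Cl)c(Cl)c3)c(SC(C)C)s2)c(C(=O)O)c1-c1cnccn1` gives 14000 nM. Compound 3 `Cc1cc(-c2c(C)nn(-c3nc(-c4ccc(Cl)c(Cl)c4)c(SC(C)C)s3)c2C(=O)O)cc(C)n1` gives 580 nM, the lowest of the three numbers; its distance from the others, a 36-fold lower number from compound 1 to compound 3 (1.56 log units; beyond the scatter) and a 24-fold lower number from compound 2 to compound 3 (1.38 log units; beyond the scatter), is large, while a 1.5-fold lower number from compound 1 to compound 2 (0.18 log units; within the scatter) is small.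

Compound 4 `CCOc1ncccc1-c1c(C)nn(-c2nc(-c3ccc(Cl)c(Cl)c3)c(SC(C)C)s2)c1C(=O)O` is not yet measured. Its change from compound 3 is 2-ethoxypyridin-3-yl in place of 2,6-dimethylpyridin-4-yl on an aromatic carbon. Among the measured compounds shown here, no measured step involves this exact group, so the expectation rests on the two large steps toward compound 3: each time the 2,6-dimethylpyridin-4-yl was absent, the number was far higher. Since compound 4 also lacks that group, a large rise is expected, though not necessarily back to the level of compound 1 or compound 2. The expected step is a 10-fold higher number from compound 3 to compound 4 (1.01 log units; beyond the scatter). Compound 4 is therefore estimated at 6000 nM, with a range from 1500 nM to 25000 nM.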

Compound 4, half-maximal effective concentration: 11000 nM
Beside the measured number, compound 4's estimate is 1.8-fold (0.26 log units) below it; the range from low to high includes it.
By their numbers in this assay, from the lowest: compound 3; then compounds 4, 2 and 1 (each within the scatter of the next).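

In this assay there is a 19-fold higher number from compound 3 to compound 4 (1.28 log units; beyond the scatter) and this is a third large step away from the 2,6-dimethylpyridin-4-yl group, now toward a group that carries an ethoxy chain on its pyridine ring. Compound 4 does not separate from the other two, with a 1.3-fold lower number from compound 2 to compound 4 (0.10 log units; within the scatter) and a 1.9-fold lower number from compound 1 to compound 4 (0.28 log units; within the scatter) both within the scatter, so three different groups on this aromatic carbon now sit together while compound 3 stands apart. A pyridine ring as such is therefore not enough for the low number, since compound 1 and compound 4 each carry one and remain high.

Open, from the compounds shown here alone, is how a pyridin-4-yl group with a single methyl, or with an amine in place of the methyls, would compare with compound 3. Nothing measured here explains why compound 3 stands apart.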